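This account rests on a few compounds, and the source may have more. Where it says the series, first, only, none or still open, it means among the compounds named here.

The series shares one core, seen in compound 1 `CC(C)(C)N(NC(=O)c1ccccc1Cl)C(=O)c1ccccc1Cl`, which in an assay on cells for agonist activity at ecdysone receptor (Bombyx mori), read by a luciferase reporter, with a stated time of 24 h (on this read-out lower numbers stand for an effect already at smaller amounts and higher numbers for an effect only at larger amounts of compound), gives 331 nM. Compound 2 `CC(C)(C)N(NC(=O)c1cccc(F)c1)C(=O)c1ccccc1Cl` gives 69.2 nM in this assay, and compound 3 `CC(C)(C)N(NC(=O)c1ccc(I)cc1)C(=O)c1ccccc1Cl` gives 7.59 nM. Compound 3 thus stands at the lowest number of the three: the step of a 44-fold lower number from compound 1 to compound 3 (1.64 log units; beyond the scatter) and the step of a 9.1-fold lower number from compound 2 to compound 3 (0.96 log units; beyond the scatter) both lie beyond the scatter, as does the step of a 4.8-fold lower number from compound 1 to compound 2 (0.68 log units; beyond the scatter).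

Compound 4 `CC(C)c1ccc(C(=O)NN(C(=O)c2ccccc2Cl)C(C)(C)C)cc1` differs from compound 3 by isopropyl in place of iodo on an aromatic carbon. Going by the values given here, no measured step swaps one group for another at this same place; each of the three moves both the position and the halogen on that ring, and their sizes ran from modest to large. Among the compounds with values here, they show only that a ring bearing a group para to a large group gave the lowest number so far; they say nothing about how an isopropyl compares with an iodo there. With the iodo kept aside and a three-carbon group put in its stead, the step is expected to be small, near a 1.6-fold higher number from compound 3 to compound 4 (0.20 log units; within the scatter), in no firm direction. Compound 4 is therefore estimated at 12 nM in this assay, within a range from 3 nM to 50 nM.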

Compound 4, half-maximal effective concentration: 24.6 nM
Beside the measured number, compound 4's estimate is 2.1-fold (0.31 log units) below it; low and high end bracket the measured number.
By their numbers in this assay, from the lowest: compound 3; then compound 4; then compound 2; then compound 1.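

In this assay, going by these compounds alone, putting isopropyl in place of iodo gives a 3.2-fold higher number from compound 3 to compound 4 (0.51 log units; beyond the scatter), and this is the first step that swaps one group for another at a single place, on an aromatic carbon para to a large group, with the rest of the structure unchanged. It shows that this place tells the two groups apart, even though neither iodo nor isopropyl has a hydrogen-bond donor, a hydrogen-bond acceptor or a net charge, so those counts alone do not set the number here. Nothing given for these compounds accounts for the difference between iodo and isopropyl.

The compounds shown leave open how a methoxy group, an amine or a carboxylic acid at this same place would compare with iodo and isopropyl, and whether a shorter chain such as ethyl or a longer one such as n-butyl would fall near either of them. They also leave open whether the gap between iodo and isopropyl would stay the same if the 2-chlorophenyl on the other carbonyl carbon were replaced.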